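Replacing the carbamoylpyrrolidine with piperidine in the series

The source may hold more compounds than are shown below. What is called first, only, known or untested is meant among the compounds shown, and "the series" means these compounds.

Measured compounds:
compound 1 `Cc1nn([C@H](C)c2ccc(Cl)cc2Cl)c2nc(N3CC[C@H](N4CCC[C@H]4C(N)=O)[C@H](C)C3)cnc12` — 170 nM
compound 2 `CC(c1ccc(Cl)cc1Cl)n1ncc2ncc(N3CCC(N4CCCCC4)CC3)nc21` — 2580 nM
compound 3 `Cc1nn([C@H](C)c2ccc(Cl)cc2Cl)c2nc(N3CC[C@H](N4CCC[C@H]4CCS(C)(=O)=O)[C@H](C)C3)cnc12` — 104 nM

In a functional assay on cells for antagonist activity at C-C chemokine receptor type 4 (Homo sapiens), read by fluorescence and calcium flux, with stated times of 2.5 s and 45 s (on this read-out higher numbers stand for weaker inhibition and lower numbers for stronger inhibition), compound 1 gives 170 nM and stands second highest of the three numbers; its nearest neighbour is compound 3 with 104 nM, its furthest compound 2 with 2580 nM, the latter beyond the scatter. Among the measured compounds shown here, the single step measured so far, a 1.6-fold lower number from compound 1 to compound 3 (0.21 log units; within the scatter), shows that exchanging the group on the saturated ring carbon can leave the number essentially unchanged.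

Compound 4 `Cc1nn([C@H](C)c2ccc(Cl)cc2Cl)c2nc(N3CC[C@H](N4CCCCC4)[C@H](C)C3)cnc12` differs from compound 1 by piperidin-1-yl in place of 2-carbamoylpyrrolidin-1-yl on a saturated ring carbon. For the measured compounds named here, no measured pair covers this exact exchange. Going by the values given here, compound 2 also carries piperidin-1-yl but differs from compound 1 in more than one place, so its values show only that the combination of changes in compound 2 gives a much higher number; the step from compound 1 to compound 3 bears on the same position but replaces carbamoyl with another substituted chain, not the ring itself. The expectation for compound 4 is therefore a moderately higher number, a 2.9-fold higher number from compound 1 to compound 4 (0.47 log units; beyond the scatter), with wide uncertainty. Compound 4 is estimated at 500 nM, range 150 nM to 1700 nM.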

Compound 4, half-maximal inhibitory concentration: 42 nM
Compound 4: middle estimate off by 12-fold (1.08 log units), on the high side; measured number outside the range, below it.
By their numbers in this assay, from the lowest: compound 4; then compounds 3 and 1 (each within the scatter of the next); then compound 2.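

In this assay, piperidin-1-yl in place of 2-carbamoylpyrrolidin-1-yl gives a 4.0-fold lower number from compound 1 to compound 4 (0.61 log units; beyond the scatter) at this saturated ring carbon, and piperidin-1-yl in place of 2-(2-(methylsulfonyl)ethyl)pyrrolidin-1-yl gives a 2.5-fold lower number from compound 3 to compound 4 (0.39 log units; beyond the scatter) at the same carbon. Among the compounds shown here, a low number at this position therefore does not depend on either the carbamoyl or the 2-(methylsulfonyl)ethyl group, and the unsubstituted six-membered ring gives the lowest number of the series so far.

Ring size and the substituent change together in both steps: the contribution of each cannot be separated without unsubstituted pyrrolidin-1-yl at this carbon. Also open, from the compounds shown here alone, is how a piperidin-1-yl ring carrying a carboxylic acid or a primary amine would read, and no measurement here explains these steps.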